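The source may report more compounds than this note shows. Statements on the series, on what has been measured and on what is new or still open speak of the compounds shown alone.

Of the compounds shown here, two have a number so far. Compound 1 `CCCCCN1CC(=O)N(C)[C@@H](Cc2ccc(-c3cc(OC)c(OC)c(OC)c3)cc2)C1=O` carries a trimethoxyphenyl arm on the shared core and in a functional assay for agonist activity at follicle-stimulating hormone receptor (Homo sapiens), read by a luciferase reporter (on this read-out higher numbers stand for an effect only at larger amounts of compound and lower numbers for an effect already at smaller amounts), compound 1 gives 9000 nM. For the measured compounds named here, compound 2 `CCCCCCCCN1C(=O)[C@H](Cc2ccc(-c3cccc(CN(CCCC)C(C)=O)c3)cc2)N(C)C(=O)[C@@H]1C` has a longer chain on the core nitrogen, a methyl on the ring, and an acetyl(butyl)amino)methyl arm on the outer phenyl; in this assay compound 2 gives 14 nM. Of the two numbers compound 2 stands at the lower one, and compound 1 lies far above it, beyond the scatter. No step between these two has been computed, since they differ in several places at once.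

Compound 3 `CCCCCCCCN1C(=O)[C@H](Cc2ccc(-c3cccc(CN(CCCC)C(=O)OC)c3)cc2)N(C)C(=O)[C@@H]1C` is the next one to be measured. It differs from compound 2 in one place: methoxy in place of methyl on a carbonyl carbon. Going by the values given here, no single-point step has been measured, so there is no direct precedent for this exchange. The expectation for compound 3 is a step of a 1.4-fold higher number from compound 2 to compound 3 (0.15 log units; within the scatter), which would stay within the scatter of the value of compound 2. The estimate for compound 3 in this assay is 20 nM, with a range from 7 nM to 60 nM.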

Compound 3, half-maximal effective concentration: 2.7 nM
The estimate for compound 3 lay 7.4-fold (0.87 log units) above the measured number; the measured number lies below the stated range.
By their numbers in this assay, from the lowest: compound 3; then compound 2; then compound 1.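

In this assay, for the compounds shown here, the first single-place step reads a 5.2-fold lower number from compound 2 to compound 3 (0.71 log units; beyond the scatter), so the carbonyl carbon on the amide-type nitrogen of the outer arm is a place where one small exchange moves the number beyond the scatter. Compounds 1 and 2 could not show this, as they differ in several places at once and their gap cannot be assigned to any one of them. Here the change is confined to acetyl to methoxycarbonyl, which adds one oxygen and one hydrogen-bond acceptor, and the rest of the molecule stays as in compound 2; nothing at hand says why the number falls with this exchange.

Still open, going by these compounds, is whether the lower number is particular to methoxy, or whether an ethoxy, a dimethylamino or a cyclopropyl on the same carbonyl carbon would give a similar step. Also open, on these data alone, is whether a longer chain in place of the butyl on the amide-type nitrogen, or the shorter chain on the core nitrogen of compound 1, would leave the step intact.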